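A few compounds are considered here, and "the series" means these few. Any claim that something is new, unique, unknown or untested is made for them only; others in the source may bear on it.

Measured compounds in a functional assay on PC-3 cells (Homo sapiens) for antiproliferative activity, read by MTT assay, tested at 1 uM; on this read-out lower numbers stand for a weaker effect and higher numbers for a stronger effect at the one concentration tested:

- compound 1 `COc1cc(C2=NN(C(C)=O)C(c3c(Cl)cccc3Cl)O2)cc(OC)c1OC` gives 5.1%
- compound 2 `COc1cc(C2=NN(C(C)=O)C(c3cc(Cl)cc(Cl)c3)O2)cc(OC)c1OC` gives 52.7%
- compound 3 `COc1cc(C2=NN(C(C)=O)C(c3ccc(F)cc3)O2)cc(OC)c1OC` gives 0%

Compound 3 stands lowest of the three. Compound 1 is its nearest neighbour, and the step of a number 5.1 percentage points lower from compound 1 to compound 3 (within the scatter) lies within the scatter, so the two cannot be told apart. Compound 2 is furthest away, and the step of a number 52.7 percentage points lower from compound 2 to compound 3 (beyond the scatter) is large and beyond the scatter.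

Compound 4 `COc1cc(C2=NN(C(C)=O)C(c3ccccc3F)O2)cc(OC)c1OC` differs from compound 3 only in the fluorophenyl group: 2-fluorophenyl in place of 4-fluorophenyl on a saturated ring carbon. Going by the values given here, no measured step moves a single fluorine from one position to another on this ring, so nothing bears on it directly. Among the compounds with values here, the only step that changes a substitution pattern without changing the atoms is a number 47.6 percentage points higher from compound 1 to compound 2 (beyond the scatter), which was large; it shows that the pattern on this ring can matter, but it concerns two chlorines rather than one fluorine, and it gives no direction for the present change. Within the data shown here, with three low or modest values and no guiding step, a small change is the most defensible expectation.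

Compound 4 is expected to give 6%, with a range from 0% to 25%. The expected step is a number 6 percentage points higher from compound 3 to compound 4 (within the scatter), within the scatter.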

Compound 4, a percentage reported as inhibition, at one concentration (the size of the read-out at that concentration, not a potency): 13.5%
For compound 4 the middle estimate is 7.5 percentage points below the measured one, and the stated range covers the measured number.
By their numbers in this assay, from the lowest: compounds 3, 1 and 4 (each within the scatter of the next, the first and the last beyond it); then compound 2.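

In this assay, moving the single fluorine without changing any atoms gives a number 13.5 percentage points higher from compound 3 to compound 4 (beyond the scatter), so the place of one fluorine on this ring counts, though only modestly, and the effect of substitution pattern is not limited to the dichlorophenyl pair. Even so, the 2-fluorophenyl group cannot be told apart from the 2,6-dichlorophenyl group, at a number 8.4 percentage points higher from compound 1 to compound 4 (within the scatter), and it remains far from the 3,5-dichlorophenyl group, at a number 39.2 percentage points lower from compound 2 to compound 4 (beyond the scatter). No measurement available here explains the effect of moving the fluorine.

The compounds shown leave open whether a single chlorine, an amine or a carboxylic acid on this phenyl ring would match the 3,5-dichlorophenyl group. With only one tested concentration, they also leave the potency of each compound open.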